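Flipping One Double Bond in a Polyacetylenic Ketone

The compounds below may be only part of what the source reports. "The series", "measured", "known", "first", "only" and "open" are said of these compounds alone.

Compound 1 `C=CCCCCCCCC#CC#C/C=C\C(C)=O` is the starting point. In a functional assay on XF498 cells (Homo sapiens) for cytotoxicity (a higher number here means that more compound is needed for the effect, a lower number that less compound is needed), compound 1 gives only a limit, > 50 ug/mL. Compound 2 `CCCCCCCC#CC#C/C=C\C(C)=O` is a close relative with a shorter chain. In this assay compound 2 also gives only a limit, > 50 ug/mL. The step between them, a step that the two limits leave unreadable from compound 1 to compound 2, therefore cannot be read. Both results sit at the limit of > 50 ug/mL in this assay, at which 2 of the 2 values shown sit, so nothing shown locates compound 1 anywhere more precisely than that boundary.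

Compound 3 `C=CCCCCCCCC#CC#C/C=C/C(C)=O` is not yet measured. Compared with compound 1, the change is the two compounds have the same atoms and bonds and differ only in configuration as drawn: 1 of 1 stereo elements differ; a double bond is drawn Z in compound 1 and E in compound 3. No measured step touches this double bond, and the single step that is shown has no readable size, so the expectation rests only on the fact that both measured compounds stay at the limit. The step that the limit leaves unreadable from compound 1 to compound 3 is therefore expected to be small or unreadable. For compound 3 in this assay, a value of 60 ug/mL is estimated, within a range from 20 ug/mL to 200 ug/mL, most likely again reported only as a limit.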

Compound 3, concentration for half-maximal effect: 3.2 ug/mL
For compound 3 the middle estimate is 19-fold (1.27 log units) above the measured one, and the stated range ends above it.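

For the compounds shown here, compound 3 is the only compound here with a real number in this assay rather than a limit, so this is the first readable sign that the structure can change the outcome in this assay. Changing the double bond from Z to E, with the same atoms and bonds kept, gives an at least 15-fold lower number from compound 1 to compound 3 (1.19 log units; beyond the scatter), a large change from an edit that adds and removes nothing. This step can be placed on that one double bond alone, because no other difference exists between the two structures: the fact that compounds 1 and 3 differ only in the configuration as drawn

On these data alone, the step between compound 1 and compound 2 still cannot be read, so the role of the vinyl end of the chain stays unknown, as does whether the E double bond would have the same effect on the shorter chain of compound 2. Also open, as far as these compounds go, is how the E compound would respond if a carboxylic acid took the place of the ketone.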